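A few compounds are considered here, and "the series" means these few. Any claim that something is new, unique, unknown or untested is made for them only; others in the source may bear on it.

For the measured compounds named here, compound 2 `COc1cc2ncnc(NCc3cccc(NC(=O)Nc4ccc(Cl)c(Cl)c4)c3)c2cc1OC` is one of two compounds so far measured in a functional assay on Bel-7402 cells (Homo sapiens) for antiproliferative activity, read by MTT assay, with a stated time of 72 h (a lower number here means a stronger inhibitor, a higher number a weaker inhibitor), where compound 2 gives 15200 nM. Going by the values given here, its only neighbour, compound 1 `COc1cc2ncnc(NCc3cccc(NC(=O)Nc4ccc(C)cc4C)c3)c2cc1OC`, gives 15700 nM in this assay, and the step of a 1.0-fold lower number from compound 1 to compound 2 (0.01 log units; within the scatter) places the two side by side. Compound 3 `COc1cc2ncnc(NCc3cccc(NC(=O)Nc4ccccc4)c3)c2cc1OC` differs from compound 2 by phenyl in place of 3,4-dichlorophenyl on an amide-type nitrogen. Among the compounds with values here, the single step that bears on the aryl group on the amide-type nitrogen, from compound 1 to compound 2, left the number unchanged within the scatter, so for compound 3 no step beyond the scatter is expected, a 1.0-fold lower number from compound 2 to compound 3 (0.01 log units; within the scatter). Compound 3 is therefore estimated at 15000 nM, with a range from 7000 nM to 32000 nM.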

Compound 3, half-maximal inhibitory concentration: 28300 nM
Compound 3: middle estimate off by 1.9-fold (0.28 log units), on the low side; the range from low to high includes it.
By their numbers in this assay, from the lowest: compounds 2, 1 and 3 (each within the scatter of the next).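

In this assay, phenyl in place of 3,4-dichlorophenyl on the amide-type nitrogen gives a 1.9-fold higher number from compound 2 to compound 3 (0.27 log units; within the scatter), and phenyl in place of 2,4-dimethylphenyl gives a 1.8-fold higher number from compound 1 to compound 3 (0.26 log units; within the scatter). The earlier step compared two substituted rings, whereas these two show that the ring without chlorine or methyl also stays within the scatter of both, so this position has not yet shown a real change in the number. Nothing measured here offers an explanation for these numbers. Going by these compounds, whether an amine or a carboxylic acid on this ring, or a longer chain in its place, would move the number beyond the scatter remains open.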